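The source may report more compounds than this note shows. Statements on the series, on what has been measured and on what is new or still open speak of the compounds shown alone.

Two compounds that share one core have so far been run in an in vitro ADME assay on microsomes from liver (Canis lupus familiaris, strain beagle) for metabolic stability, using NADPH, with a stated time of 10 min, tested at 0.5 uM; a higher number here means that the compound lasts longer, a lower number that the compound disappears faster. Compound 1 `COc1ccccc1-c1ccc2cnc(Nc3ccc(S(=O)(=O)N(C)C)cc3)nn12` gives 0.117 h in this assay. Compound 2 `COc1ccccc1-c1ccc2cnc(Nc3cccc(N4CCN(C)CC4)c3)nn12` gives 0.0833 h in this assay, the lower of the two numbers, yet its gap to compound 1 lies within the scatter, so the two cannot be ordered against each other. Compound 3 `COc1ccccc1-c1ccc2cnc(Nc3cccc(N4CCN(C[C@H](C)O)CC4)c3)nn12` has not yet been measured. It differs from compound 2 in a single place: 1-hydroxyethyl in place of hydrogen on a saturated chain carbon bound to an amine nitrogen in a ring. Within the data shown here, no measured pair shows what such a change does here, so any expectation rests only on the change itself and on where compound 2 stands. The step from compound 2 to compound 3 in this assay is expected to be small, a 1.2-fold higher number from compound 2 to compound 3 (0.08 log units; within the scatter), and not to reach beyond the scatter in either direction. On that basis compound 3 is estimated at 0.1 h, with a range from 0.05 h to 0.25 h.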

Compound 3, half-life: 0.15 h
Compound 3: middle estimate off by 1.5-fold (0.18 log units), on the low side; low and high end bracket the measured number.
By their numbers in this assay, from the lowest: compounds 2, 1 and 3 (each within the scatter of the next).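

Among these compounds, compound 3 gives the first reading of a change at this position: going from 4-methylpiperazin-1-yl to 4-(2-hydroxypropyl)piperazin-1-yl gives, in this assay, a 1.8-fold higher number from compound 2 to compound 3 (0.26 log units; within the scatter) and so stays within the scatter. This position therefore accepts a larger group carrying a hydroxyl without a measurable shift in half-life, so compound 2 and compound 3 cannot be told apart here. Nothing at hand explains why the numbers fall where they do.

Still open, as far as these compounds go, is whether a longer chain such as 3-hydroxypropyl, a chain ending in a carboxylic acid, or the mirror-image form of the 2-hydroxypropyl group would give a step beyond the scatter. With a single step at this position, it is also unknown whether the same change would behave alike on another core.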